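Removing the Amino Group from the Shared Core

A few compounds are considered here, and "the series" means these few. Any claim that something is new, unique, unknown or untested is made for them only; others in the source may bear on it.

Compound 2 `CCCCc1ccc(Nc2nc(N)c3ncn([C@@H]4C[C@@H](O)[C@H](CO)O4)c3n2)cc1` stands lowest of the two measured compounds in a functional assay on HeLa cells (Homo sapiens) for inhibition, with a stated time of 3 h, tested at 100 uM (on this read-out lower numbers stand for less inhibition and higher numbers for more inhibition at the one concentration tested (going by the name of the read-out)), where compound 2 gives 56%. Compound 1 `CCCCc1ccc(Nc2nc(Cl)c3ncn([C@@H]4C[C@@H](O)[C@H](CO)O4)c3n2)cc1` carries chloro in place of that amino, and in this assay compound 1 gives 87%, the step being a number 31 percentage points lower from compound 1 to compound 2 (beyond the scatter). Compound 3 `CCCCc1ccc(Nc2ncc3ncn([C@@H]4C[C@@H](O)[C@H](CO)O4)c3n2)cc1` differs from compound 2 by hydrogen in place of amino on an aromatic carbon. For the measured compounds named here, no measured step covers hydrogen at this position; only chloro against amino has been compared, and the direction for hydrogen remains open. Compound 3 is estimated at 65%, with a range from 35% to 90%, which means an expected step of a number 9 percentage points higher from compound 2 to compound 3 (within the scatter).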

Compound 3, a percentage reported as inhibition, at one concentration (the size of the read-out at that concentration, not a potency): 58%
Compound 3: middle estimate off by 7 percentage points, on the high side; low and high end bracket the measured number.
By their numbers in this assay, from the lowest: compounds 2 and 3 (each within the scatter of the next); then compound 1.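

In this assay hydrogen in place of amino gives a number 2 percentage points higher from compound 2 to compound 3 (within the scatter) so these two groups cannot be told apart at this position. Hydrogen in place of chloro gives a number 29 percentage points lower from compound 1 to compound 3 (beyond the scatter) so among the three groups compared here, only chloro stands apart from the others. Nothing available explains why chloro differs from amino and hydrogen. Whether other groups on this aromatic carbon would read like chloro remains open, as bromo and methoxy do not appear among the compounds shown.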